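Methyl for Chloro on the Urea Aryl Ring of Compound 2

The compounds below may be only part of what the source reports. "The series", "measured", "known", "first", "only" and "open" are said of these compounds alone.

Of the compounds shown here, two sharing one core have been tested in a functional assay on HT-29 cells (Homo sapiens) for cytotoxicity, read by MTT assay, with a stated time of 72 h; a lower number here means a stronger inhibitor, a higher number a weaker inhibitor. Compound 1 `CCN(CC)CCCNc1nc(-c2ccc(NC(=O)Nc3ccc(C)cc3)cc2)nc2c(Cl)c(Cl)sc12` gives 890 nM in this assay. Compound 2 `CCN(CC)CCNc1nc(-c2ccc(NC(=O)Nc3ccc(Cl)cc3)cc2)nc2c(Cl)c(Cl)sc12`, which carries a shorter chain on the amine and a chloro in place of the methyl on the outer urea ring, gives 430 nM in this assay. Of the two numbers, compound 2 has the lower one, and the gap to compound 1 lies beyond the scatter of repeated measurements; since compounds 1 and 2 differ in two places, the two values alone do not say which change carries that gap.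

Compound 3 `CCN(CC)CCNc1nc(-c2ccc(NC(=O)Nc3ccc(C)cc3)cc2)nc2c(Cl)c(Cl)sc12` is yet to be measured. It differs from compound 2 in one place: methyl in place of chloro on an aromatic carbon. Compound 3 thus also stands one change away from compound 1, sharing its methyl and differing only in the chain. A step of modest size toward a higher number, possibly no larger than the scatter, is expected from compound 2 to compound 3 a 1.6-fold higher number from compound 2 to compound 3 (0.21 log units; within the scatter). Compound 3 is estimated at 700 nM in this assay, within a range from 300 nM to 1600 nM.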

Compound 3, half-maximal inhibitory concentration: 950 nM
Estimate against measurement, compound 3: 1.4-fold (0.13 log units) below; low and high end bracket the measured number.
By their numbers in this assay, from the lowest: compound 2; then compounds 1 and 3 (each within the scatter of the next).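

In this assay the exchange of 4-chlorophenyl to 4-methylphenyl on the urea, with the chain held fixed, gives a step that clears the scatter, though only modestly (a 2.2-fold higher number from compound 2 to compound 3 (0.34 log units; beyond the scatter)), so this place on the outer ring does register the change from chloro to methyl. With the methyl held fixed, the change in the chain leaves the two numbers within the scatter of each other (a 1.1-fold higher number from compound 1 to compound 3 (0.03 log units; within the scatter)), which assigns the gap between the two earlier compounds, unresolved by their values alone, to the exchange on the ring and not to the chain. No measurement shown here accounts for why chloro and methyl read differently at this place.

The compounds shown leave open whether the chain change would read the same with chloro on the ring, since the single chain step rests on the methyl series alone. They also leave open how a fluoro, a methoxy or a trifluoromethyl at this same ring carbon would compare with chloro and methyl.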